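Replacing cyclopropylamino on the shared core with pyridinylpiperazinyl

The source may report more compounds than this note shows. Statements on the series, on what has been measured and on what is new or still open speak of the compounds shown alone.

Compound 1 `O=C(Nc1ccccc1)Nc1nc(NC2CC2)cc(Sc2c[nH]c3ccccc23)n1`: > 50000 nM
Compound 2 `Cc1ccc(NC(=O)Nc2nc(Nc3ccccc3)cc(Sc3c[nH]c4ccccc34)n2)cc1`: 23500 nM

Two compounds carry a measured value in a functional assay on A549 cells (Homo sapiens) for inhibition, with a stated time of 72 h; a higher number here means a weaker inhibitor, a lower number a stronger inhibitor. Compound 1 reaches only the limit of the assay, > 50000 nM, and no number stands behind it. Compound 2 differs from compound 1 in two places. In this assay compound 2 gives 23500 nM. Among the measured compounds shown here, no single-change step connects the two measured compounds, so only the two values themselves can be set side by side. Compound 1 thus sits at the weak end, on the limit, where (the limit of > 50000 nM in this assay, at which 1 of the 2 values shown sits).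

Compound 3 `O=C(Nc1ccccc1)Nc1nc(Sc2c[nH]c3ccccc23)cc(N2CCN(c3ccccn3)CC2)n1` has not been measured. It differs from compound 1 by 4-(pyridin-2-yl)piperazin-1-yl in place of cyclopropylamino on an aromatic carbon, in words 4-(pyridin-2-yl)piperazin-1-yl in place of cyclopropylamino on an aromatic carbon. For the measured compounds named here, no measured step speaks to this exchange. Starting from a limit, the step from compound 1 to compound 3 is expected to be an at least 1.6-fold lower number from compound 1 to compound 3 (0.22 log units; that floor lies within the scatter), most likely a modest gain that stays close to the weak end. Compound 3 is therefore estimated at 30000 nM in this assay, with a range from 5000 nM to 100000 nM.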

Compound 3, half-maximal inhibitory concentration: 30300 nM
For compound 3 the middle estimate is 1.0-fold (0.00 log units) below the measured one; low and high end bracket the measured number.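

In this assay, among the compounds shown here, compound 3 gives 30300 nM, the first number on the core of compound 1 with a group other than cyclopropylamino on this aromatic carbon, and it shows that 4-(pyridin-2-yl)piperazin-1-yl, with its two rings, still leaves a value that can be read inside the assay. The change amounts to an at least 1.6-fold lower number from compound 1 to compound 3 (0.21 log units; that floor lies within the scatter), so the data fix only a floor for the step and do not establish a gain beyond the scatter. Going by these compounds, compound 1 stands on a limit of the assay, which is not a number, and the true size of the step stays unknown: the limit of > 50000 nM in this assay, at which 1 of the 3 values shown sits.

The compounds shown leave open which part of the entering group goes with the readable value, the piperazine ring or the pyridine attached to it, since the two enter together in a single exchange. Also open, on these data alone, is how a morpholine, a piperazine bearing only a methyl group, or a simple dimethylamino group on the same carbon would read in this assay.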